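The source may report more compounds than this note shows. Statements on the series, on what has been measured and on what is new or still open speak of the compounds shown alone.

In a functional assay on HT-29 cells (Homo sapiens) for inhibition, read by sulforhodamine B assay, with a stated time of 48 h (on this read-out higher numbers stand for weaker inhibition of growth and lower numbers for stronger inhibition of growth), compound 3 `Cc1ccc(-c2c(CNC(C)(C)C)c(C(=O)O)nn2-c2ccccc2)cc1` has no exact number: its entry of > 688000 nM is a limit of the assay. Compound 2 `CC(C)(C)NCc1c(C(=O)O)nn(-c2ccccc2)c1-c1ccc(F)cc1` also has only a limit, > 680000 nM. For the measured compounds named here, compound 1 `CCOC(=O)c1nn(-c2ccccc2)c(-c2ccc([N+](=O)[O-])cc2)c1CNC(C)(C)C` is the only one with actual numbers, 71300 nM; 35100 nM (2 entries).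

Compound 4 `CC(C)(C)NCc1c(C(=O)O)nn(-c2ccccc2)c1-c1ccc([N+](=O)[O-])cc1` differs from compound 3 in one place, nitro in place of methyl on an aromatic carbon, turning 4-methylphenyl into 4-nitrophenyl. Going by the values given here, the one measured swap of this kind is a step that the two limits leave unreadable from compound 2 to compound 3, so it offers no size to carry over. Compound 1 also carries 4-nitrophenyl, and its 71300 nM; 35100 nM (2 entries) shows that a compound with this group can give a number here, but it is not the same compound. Growth inhibition stayed out of reach across the swap a step that the two limits leave unreadable from compound 2 to compound 3, so no step beyond the scatter is expected here. The expected change is an at least 1.1-fold lower number from compound 3 to compound 4 (0.05 log units; that floor lies within the scatter). Compound 4 is estimated at 600000 nM, with an expected range of 200000 nM to 900000 nM, and it may well report only a limit.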

Compound 4, concentration for 50% growth inhibition: > 634000 nM
Compound 4: no number, only a limit; the forecaster's own chance of this, stated with the estimate: 75%; at least 1.0-fold (0.02 log units) between middle value and limit.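

For the compounds shown here, compound 2, compound 3 and compound 4 each give only a limit in this assay, and no step among them can be read. The compounds shown leave open whether swapping fluoro, methyl and nitro at this place changes growth inhibition at all, and by how much.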